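The compounds below may be only part of what the source reports. "The series", "measured", "known", "first", "only" and "open" are said of these compounds alone.

Compound 1 `C/C(=N\Nc1nc2ccccc2o1)c1cnc(C)cn1`: 150 nM
Compound 2 `C/C(=N\Nc1nc2ccccc2o1)c1nccnc1C`: 900 nM

In a functional assay on cells (Burkitts lymphoma cell, Homo sapiens) for antiproliferative activity, read by MTT assay (a lower number here means a stronger inhibitor, a higher number a weaker inhibitor), compound 2 stands at the higher of the two numbers, and its gap to compound 1 lies beyond the scatter. Compound 3 `C/C(=N\Nc1nc2ccccc2o1)c1cnccn1` is not yet measured. It differs from compound 2 by hydrogen in place of methyl on an aromatic carbon, next to the ring nitrogen and ortho to a large group. Going by the values given here, no measured pair isolates this change, and no measured compound lacks a methyl, so the expectation is uncertain. In this assay, a step toward a lower number, beyond the scatter, is expected: compound 1 at 150 nM shows that a lower number than that of compound 2 at 900 nM is reachable in this series. The expected change is a 3.6-fold lower number from compound 2 to compound 3 (0.56 log units; beyond the scatter). For compound 3 the estimated value is 250 nM, with an expected range of 80 nM to 800 nM.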

Compound 3, half-maximal inhibitory concentration: 280 nM
The estimate for compound 3 lay 1.1-fold (0.05 log units) below the measured number; low and high end bracket the measured number.
By their numbers in this assay, from the lowest: compounds 1 and 3 (each within the scatter of the next); then compound 2.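

Under this assay hydrogen in place of methyl on an aromatic carbon, next to the ring nitrogen and ortho to a large group, gives a 3.2-fold lower number from compound 2 to compound 3 (0.51 log units; beyond the scatter) and so shows that the weaker number of compound 2 goes with the methyl at this place. The same replacement starting from compound 1 gives a 1.9-fold higher number from compound 1 to compound 3 (0.27 log units; within the scatter) and so leaves no readable effect of the methyl at its place in compound 1, which means that in these compounds the effect depends on where the methyl sits. No measured evidence bears on the reason for this difference.

Going by these compounds, only methyl and hydrogen have been compared at this place, so the response to an ethyl, a methoxy or an amine there remains open. On these data alone, whether a chlorine or a longer chain would track with the methyl of compound 2 also remains open.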